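The compounds below may be only part of what the source reports. "The series", "measured", "known", "first", "only" and "open" are said of these compounds alone.

Working notes on the series. All four compounds share one core and differ only on a saturated chain carbon bound to an amine nitrogen in a ring. Compound 1 `CCN1CCc2c(sc(NC(=O)Nc3ccc(Br)cc3)c2C(N)=O)C1` gives in a functional assay (strain AB) with Danio rerio as the target, read by microscopy, with a stated time of 1 h (a higher number here means that more compound is needed for the effect, a lower number that less compound is needed), a half-maximal effective concentration of 3130 nM. Compound 2 `CC(C)CN1CCc2c(sc(NC(=O)Nc3ccc(Cl)cc3)c2C(N)=O)C1` gives in this assay 4510 nM. Compound 3 `CC(C)(C)OC(=O)CN1CCc2c(sc(NC(=O)Nc3ccc(Cl)cc3)c2C(N)=O)C1` gives in this assay only > 25000 nM, which is a limit of the assay and not a number. On the numbers shown compound 3 stands at the weak end because the limit of > 25000 nM in this assay, at which 1 of the 3 values shown sits, is where it sits.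

Compound 4 `NC(=O)c1c(NC(=O)Nc2ccc(Cl)cc2)sc2c1CCN(CC1CCC1)C2` differs from compound 3 by cyclobutyl in place of tert-butoxycarbonyl on a saturated chain carbon bound to an amine nitrogen in a ring. Among the measured compounds shown here, the one measured step that bears on this is an at least 5.5-fold higher number from compound 2 to compound 3 (0.74 log units; beyond the scatter), in which the tert-butoxycarbonyl entered and the number rose. The change to compound 4 removes that group again and puts a small ring of carbon only in its place, so a step back toward the number of compound 2 is expected in this assay. For compound 4 a half-maximal effective concentration of 4000 nM is estimated, in the range 1500 nM to 12000 nM. The expected step is an at least 6.2-fold lower number from compound 3 to compound 4 (0.79 log units; beyond the scatter).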

Compound 4, half-maximal effective concentration: 1360 nM
For compound 4 the middle estimate is 2.9-fold (0.47 log units) above the measured one; measured number below the stated range.
By their numbers in this assay, from the lowest: compound 4; then compounds 1 and 2 (each within the scatter of the next). At a limit, above all of these: compound 3.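

With cyclobutyl in place of isopropyl on a saturated chain carbon bound to an amine nitrogen in a ring, this assay shows a 3.3-fold lower number from compound 2 to compound 4 (0.52 log units; beyond the scatter), so this place still changes the number among groups without a carbonyl, and a small carbon ring is accepted there. Cyclobutyl in place of tert-butoxycarbonyl gives an at least 18-fold lower number from compound 3 to compound 4 (1.26 log units; beyond the scatter), which reverses the earlier rise seen with the tert-butoxycarbonyl and goes past the number of compound 2. That step has only a lower bound, as compound 3 stands at a limit of the assay and not at a number: the limit of > 25000 nM in this assay, at which 1 of the 4 values shown sits.

Going by these compounds, it remains open whether a cyclopropyl or cyclopentyl group would follow cyclobutyl, or whether the ring matters at all. On these data alone, it is also open whether the loss with tert-butoxycarbonyl belongs to the carbonyl or the tert-butyl part, which a carboxylic acid or a simple amide at this place would help to separate.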